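The compounds below may be only part of what the source reports. "The series", "measured", "known", "first", "only" and "open" are said of these compounds alone.

Working notes on the series in a functional assay on HepG2 cells (Homo sapiens) for antiproliferative activity, read by colorimetric assay and MTT assay, with a stated time of 48 h; a lower number here means a stronger inhibitor, a higher number a weaker inhibitor. Compound 1 (`Cc1ccc(S(=O)(=O)NC(=O)c2cccnc2)cc1`) gives 12300 nM, compound 2 (`O=C(NS(=O)(=O)c1ccc(F)cc1)c1cncc(C(=O)NS(=O)(=O)c2ccc(F)cc2)c1`) gives 6200 nM, and compound 3 (`O=C(NS(=O)(=O)c1ccc(F)cc1)c1ccncc1`) gives 12400 nM. Compound 3 is level with compound 1 and also lies within the scatter of compound 2, so these three values cannot be ranked.

The next compound is compound 4 (`O=C(NS(=O)(=O)c1ccc(Cl)cc1)c1ccncc1`). It keeps the rest of compound 3 and has chloro in place of fluoro on an aromatic carbon, para to a large group: chloro in place of fluoro on an aromatic carbon.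

Among the compounds with values here, no measured pair in this small set differs in one place only, so the data offer no direct precedent for this exchange. The closest guide is indirect: compound 3 at 12400 nM and compound 1 at 12300 nM differ in more than one place, yet their values are level. On that basis, no step beyond the scatter is expected in this assay, and any shift in either direction should be small, with a slight lean toward a lower number. The estimated change is a 1.2-fold lower number from compound 3 to compound 4 (0.09 log units; within the scatter). For compound 4 the expected value is 10000 nM, with an estimated range from 5000 nM to 20000 nM.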

Compound 4, half-maximal inhibitory concentration: 7900 nM
Estimate against measurement, compound 4: 1.3-fold (0.10 log units) above; measured number inside the range.
By their numbers in this assay, from the lowest: compounds 2, 4, 1 and 3 (each within the scatter of the next).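

Fluoro and chloro at this position, on an aromatic carbon para to a large group, now form the first comparison in the series that differs in one place only: in this assay the exchange gives a 1.6-fold lower number from compound 3 to compound 4 (0.20 log units; within the scatter) and stays short of a separable change. At this position, therefore, the two halogens cannot be ranked, and the exchange of fluoro for chloro gives no reading of a real gain or loss in antiproliferative activity. Nothing in hand accounts for the size of this step or gives any measured property of either group that bears on it.

On these data alone, whether this position responds to a group other than a halogen remains open: an amine, a carboxylic acid or a longer chain there could give a step beyond the scatter, or none at all. As far as these compounds go, compound 1 and compound 2 each differ from compound 4 in more than one place, so they cannot settle this question, and whether the same exchange behaves alike on another core also stays open.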